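Toward compound 4: adding a methoxy group on the phenyl ring

The source may report more compounds than this note shows. Statements on the series, on what has been measured and on what is new or still open speak of the compounds shown alone.

Compound 1 `Cn1c(-c2ccccc2)cnc1NC(=O)c1ccc(F)cc1` — in a toxicity assay on THP-1 cells (Homo sapiens) for inhibition (a lower number here means that less compound is tolerated, a higher number that more compound is tolerated), compound 1 gives only an assay limit, > 100000 nM.
Compound 2 `Cn1c(-c2ccccc2)cnc1NC(=O)c1ccccc1` — in this assay compound 2 gives only a limit, > 100000 nM.
Compound 3 `Cn1c(-c2ccccc2)cnc1NC(=O)c1ccc(Cl)cc1` — in this assay compound 3 gives only a limit, > 100000 nM.

Compound 3 thus sits at the limit of > 100000 nM in this assay, at which 3 of the 3 values shown sit, as do the other two. For the measured compounds named here, the steps among them, a step that the two limits leave unreadable from compound 1 to compound 2, a step that the two limits leave unreadable from compound 1 to compound 3 and a step that the two limits leave unreadable from compound 2 to compound 3, cannot be sized, so they show only that none of these changes brought toxicity into the measured range.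

Compound 4 `COc1ccc(-c2cnc(NC(=O)c3ccc(Cl)cc3)n2C)cc1` differs from compound 3 by methoxy in place of hydrogen on an aromatic carbon. No measured step involves a methoxy group, so the only guide is that every shown compound tolerated the full tested range. Compound 4 is therefore expected to behave alike, a step that the limit leaves unreadable from compound 3 to compound 4, giving an estimated 150000 nM with a range of 50000 nM to 500000 nM, most likely again reported as a limit.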

Compound 4, half-maximal cytotoxic concentration: > 100000 nM
Compound 4: a limit, no number; the forecaster's own chance of this, stated with the estimate: 85%; the middle value lies beyond the limit too.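

Compound 3 and compound 4 both give only a limit, so the size of the step between them cannot be read: the limit of > 100000 nM in this assay, at which 4 of the 4 values shown sit.

The compounds shown leave open at what concentration any of them would become toxic in this assay, and whether the methoxy group alters that concentration.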